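This account rests on a few compounds, and the source may have more. Where it says the series, first, only, none or still open, it means among the compounds named here.

Working notes on the series. Compound 1 `COC(=O)CC(=O)NC1=CS(=O)(=O)O[C@@]12[C@@H](CO[Si](C)(C)C(C)(C)C)O[C@@H](n1cc(C)c(=O)n(C)c1=O)[C@@H]2O[Si](C)(C)C(C)(C)C` gives in a functional assay on HEL cells (Homo sapiens) (on this read-out lower numbers stand for higher toxicity in this test and higher numbers for lower toxicity in this test), a value of 29000 nM. Compound 2 `CCOC(=O)CNC(=O)NC1=CS(=O)(=O)O[C@@]12[C@@H](CO[Si](C)(C)C(C)(C)C)O[C@@H](n1cc(C)c(=O)n(C)c1=O)[C@@H]2O[Si](C)(C)C(C)(C)C` gives in this assay a value of 13000 nM; the step between them is a 2.2-fold lower number from compound 1 to compound 2 (0.35 log units; beyond the scatter). Compound 3 `CC(=O)NC1=CS(=O)(=O)O[C@@]12[C@@H](CO[Si](C)(C)C(C)(C)C)O[C@@H](n1cc(C)c(=O)n(C)c1=O)[C@@H]2O[Si](C)(C)C(C)(C)C` carries the acetamido group. In this assay compound 3 reaches only the limit of the test, > 200000 nM, so a bound rather than a number is known for it. Paring back to compound 3 gives an at least 6.8-fold higher number from compound 1 to compound 3 (0.83 log units; beyond the scatter) and an at least 15-fold higher number from compound 2 to compound 3 (1.18 log units; beyond the scatter); both these steps end at the limit of > 200000 nM in this assay, at which 1 of the 3 values shown sits, so their true size is open.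

Compound 4 `Cc1cn([C@@H]2O[C@H](CO[Si](C)(C)C(C)(C)C)[C@@]3(OS(=O)(=O)C=C3NCC(=O)O)[C@H]2O[Si](C)(C)C(C)(C)C)c(=O)n(C)c1=O` is not yet measured. It differs from compound 3 by carboxymethyl in place of acetyl on an amine nitrogen. Among the compounds with values here, the steps from compounds 1 and 2 to compound 3 show that chains bearing an ester lower the number, so the return of a chain, here a carboxymethyl, may move the number back down; but no measured compound carries a free acid, and the earlier steps were themselves bounded by the limit. The expected step is an at least 1.3-fold lower number from compound 3 to compound 4 (0.12 log units; that floor lies within the scatter), a modest move downward, with a fair chance that the limit is reported again. Compound 4 is estimated at 150000 nM, between 40000 nM and 400000 nM.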

Compound 4, half-maximal cytotoxic concentration: 136000 nM
Estimate against measurement, compound 4: 1.1-fold (0.04 log units) above, and the stated range covers the measured number.
By their numbers in this assay, from the lowest: compound 2; then compound 1; then compound 4. At a limit, above all of these: compound 3.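

On an amine nitrogen, the carboxymethyl of compound 4 gives a measured number in this assay, whereas the acetyl of compound 3 gave only a limit. Carboxymethyl does not bring back the low numbers of the ester-bearing chains, with a 10-fold higher number from compound 2 to compound 4 (1.02 log units; beyond the scatter) and a 4.7-fold higher number from compound 1 to compound 4 (0.67 log units; beyond the scatter), although each of these steps replaces the whole substituent on that nitrogen. The remaining step is an at least 1.4-fold lower number from compound 3 to compound 4 (0.16 log units; that floor lies within the scatter), and its true size stays open: the limit of > 200000 nM in this assay, at which 1 of the 4 values shown sits.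

Going by these compounds, whether the methyl ester of the carboxymethyl chain, with no further carbonyl on the amine nitrogen, would sit nearer compound 1 or compound 4 remains open. Also open, on these data alone, is how a longer chain ending in a carboxylic acid, or a chain ending in a primary amine, would read on this nitrogen.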